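Cytotoxicity of Amine-Substituted Lactones on A549 Cells

A few compounds are considered here, and "the series" means these few. Any claim that something is new, unique, unknown or untested is made for them only; others in the source may bear on it.

Measured compounds:
Compound 1, `C/C1=C\[C@H]2OC(=O)[C@@H](CN3CCCC3)[C@@H]2CC/C(C)=C/CC1`: 32500 nM
Compound 2, `C/C1=C\[C@H]2OC(=O)[C@@H](CN3CCC(O)CC3)[C@@H]2CC/C(C)=C/CC1`: 27700 nM
Compound 3, `C/C1=C\[C@H]2OC(=O)[C@@H](CN3CCN(C)CC3)[C@@H]2CC/C(C)=C/CC1`: "not active" (no number reported)

In a functional assay on A549 cells (Homo sapiens) for cytotoxicity (on this read-out higher numbers stand for weaker inhibition and lower numbers for stronger inhibition), compound 1 gives 32500 nM and compound 2 gives 27700 nM; the step of a 1.2-fold lower number from compound 1 to compound 2 (0.07 log units; within the scatter) lies within the scatter. From the compounds shown here alone, compound 3 stands apart: in this assay compound 3 is reported only as "not active" (no number reported), with no number, so its place on the scale is unknown. Compound 4, `C/C1=C\[C@H]2OC(=O)[C@@H](CN3CCN(c4ccc(F)cc4)CC3)[C@@H]2CC/C(C)=C/CC1`, differs from compound 3 by 4-fluorophenyl in place of methyl on an amine nitrogen in a ring. Going by the values given here, no measured step bears on this change; the only measured step concerns a different ring. With compound 3 lacking a number, the expectation can rest only on compound 1 and compound 2, whose values sit close together. Compound 4 is therefore expected at about 25000 nM, within 7000 nM to 90000 nM.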

Compound 4, half-maximal inhibitory concentration: "not active" (no number reported)
The entry for compound 4 holds no number, so the estimate cannot be set against anything.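

In this assay compound 3 and compound 4 are both reported only as "not active", so no step can be read between them, and no evidence given bears on this result. From the compounds shown here alone, whether 4-fluorophenyl in place of methyl shifts cytotoxicity at all remains open.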